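Estimating clearance after closing a pentan-3-yl chain into cyclopentyl

The compounds below may be only part of what the source reports. "The series", "measured", "known", "first", "only" and "open" are said of these compounds alone.

Values in an ADME assay on microsomes from liver (Rattus norvegicus) for metabolic stability; a lower number here means slower removal, a higher number faster removal of the compound:
- compound 1 `Cc1cnc(-c2cc(Oc3ccc(S(C)(=O)=O)cc3)cc(OC(C)C)c2)[nH]c1=O` gives 189 mL/min/kg
- compound 2 `CC(C)Oc1cc(Oc2cnc(C(=O)N(C)C)nc2)cc(-c2nccc(=O)[nH]2)c1` gives < 25.4 mL/min/kg, a limit of the assay
- compound 3 `CCC(CC)Oc1cc(Oc2cnc(C(=O)N(C)C)nc2)cc(-c2nccc(=O)[nH]2)c1` gives 91 mL/min/kg

Two of these clearances are true numbers. Compound 1 stands at 189 mL/min/kg and compound 3 is lower at 91 mL/min/kg, a gap beyond the scatter. The value of compound 2 is a limit and not a number.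

Compound 4 `CN(C)C(=O)c1ncc(Oc2cc(OC3CCCC3)cc(-c3nccc(=O)[nH]3)c2)cn1` has not yet been measured. It differs from compound 3 by cyclopentyl in place of pentan-3-yl on an oxygen on an aromatic ring, with cyclopentyl in place of pentan-3-yl on an oxygen on an aromatic ring. The entering group holds one five-membered non-aromatic ring of carbon only.

Going by the values given here, one measured step bears on this change: an at least 3.5-fold higher number from compound 2 to compound 3 (0.55 log units; beyond the scatter), which lies beyond the scatter and came with pentan-3-yl in place of isopropyl. That step added carbon, whereas the change to compound 4 adds none and only closes a ring. Starting from compound 3 at 91 mL/min/kg, no step beyond the scatter is therefore expected in this assay, though a slightly lower number is possible. The expected step is a 1.4-fold lower number from compound 3 to compound 4 (0.15 log units; within the scatter). For compound 4 the estimated clearance is 65 mL/min/kg, with an expected range of 30 mL/min/kg to 140 mL/min/kg.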

Compound 4, clearance: 106 mL/min/kg
Compound 4: middle estimate off by 1.6-fold (0.21 log units), on the low side, within the range that was stated.
By their numbers in this assay, from the lowest: compounds 3, 4 and 1 (each within the scatter of the next, the first and the last beyond it). At a limit, below all of these: compound 2.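

In this assay, closing the open pentan-3-yl chain into a cyclopentyl ring on the same oxygen leaves clearance within the scatter, with a 1.2-fold higher number from compound 3 to compound 4 (0.07 log units; within the scatter), so at this position the chain and the ring, each of 5 carbon, cannot be told apart. Both also stand apart from isopropyl, since the ring gives an at least 4.1-fold higher number from compound 2 to compound 4 (0.62 log units; beyond the scatter) and the chain gives an at least 3.5-fold higher number from compound 2 to compound 3 (0.55 log units; beyond the scatter), which shows that the gap from isopropyl is seen with the ring as well as with the open chain, at least for these three compounds. The value of compound 2 is a limit of the assay, not a number: the limit of < 25.4 mL/min/kg in this assay, at which 1 of the 4 values shown sits.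

The compounds shown do not tell how clearance would respond to a group of intermediate size at this oxygen, such as cyclobutyl or cyclopropylmethyl, where the gap from isopropyl might open or might not. They also leave open whether putting an oxygen into the ring, as in tetrahydrofuranyl, or adding an amine to it would keep clearance closer to that of compound 2.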